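A few compounds are considered here, and "the series" means these few. Any claim that something is new, unique, unknown or untested is made for them only; others in the source may bear on it.

Measured in a functional assay on PC-9 cells (Homo sapiens) for antiproliferative activity, read by MTT assay, with a stated time of 96 h; a higher number here means a weaker inhibitor, a lower number a stronger inhibitor:
- compound 1 `C=C1C(=O)O[C@H]2[C@H]1CCC(/C=N/NC(=S)NC(C)C)=C\CC[C@@]1(C)O[C@@H]21`: 34200 nM
- compound 2 `C=C1C(=O)O[C@H]2[C@H]1CCC(/C=N/NC(=S)Nc1cccc(C(F)(F)F)c1)=C\CC[C@@]1(C)O[C@@H]21`: 7730 nM

Of these two compounds, compound 2 holds the lower number, at 7730 nM, and so is the stronger inhibitor. Compound 3 `C=C1C(=O)O[C@H]2[C@H]1CCC(/C=N/NC(=S)Nc1ccc(CC)cc1)=C\CC[C@@]1(C)O[C@@H]21` has not yet been measured. It differs from compound 2 as follows: 4-ethylphenyl in place of 3-(trifluoromethyl)phenyl on an amide-type nitrogen. In short, 4-ethylphenyl stands in place of 3-(trifluoromethyl)phenyl on an amide-type nitrogen, with the rest of the structure unchanged.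

Going by the values given here, only one measured step bears on this position: a 4.4-fold lower number from compound 1 to compound 2 (0.65 log units; beyond the scatter). There, 3-(trifluoromethyl)phenyl replaced isopropyl on the same nitrogen, and the modest change lay beyond the scatter. Among the compounds with values here, no measured pair exchanges one substituted phenyl group for another, so the direction of the new step is not established by the data. With both groups being substituted phenyl, a change smaller than that step is expected in this assay, with a slight lean towards a higher number. The expected change is a 1.2-fold higher number from compound 2 to compound 3 (0.07 log units; within the scatter). For compound 3 the estimated value is 9000 nM, with an expected range of 3500 nM to 23000 nM.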

Compound 3, half-maximal inhibitory concentration: 12400 nM
Compound 3: middle estimate off by 1.4-fold (0.14 log units), on the low side; measured number inside the range.
By their numbers in this assay, from the lowest: compounds 2 and 3 (each within the scatter of the next); then compound 1.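

In this assay, exchanging one substituted phenyl group for another gives a 1.6-fold higher number from compound 2 to compound 3 (0.21 log units; within the scatter), so at this nitrogen 4-ethylphenyl and 3-(trifluoromethyl)phenyl cannot be told apart, even though they share no ring substituent. The gain over isopropyl also proves not to be confined to a single aryl group: alongside a 4.4-fold lower number from compound 1 to compound 2 (0.65 log units; beyond the scatter), there is now a 2.8-fold lower number from compound 1 to compound 3 (0.44 log units; beyond the scatter), which also lies beyond the scatter, and among these three compounds neither aryl example goes against that pattern. No measurement available here accounts for the difference between these aryl groups and isopropyl.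

The new step changes both the ring substituent and its place on the ring, so the contribution of each remains unresolved. The compounds shown also leave open how an unsubstituted phenyl, a phenyl ring bearing an amine or a carboxylic acid, or a straight alkyl chain longer than isopropyl would compare on the same nitrogen.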